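Compound 3 to compound 4: aryl exchange on the thiocarbonyl series

This account rests on a few compounds, and the source may have more. Where it says the series, first, only, none or still open, it means among the compounds named here.

Measured in a functional assay on U-373MG ATCC cells (Homo sapiens) for inhibition, read by MTT assay, with a stated time of 72 h; a lower number here means a stronger inhibitor, a higher number a weaker inhibitor:
- compound 1 `CC1(C)CC(NC(=S)NCc2ccccc2)c2cc(F)ccc2O1` gives 27000 nM
- compound 2 `CC1(C)CC(NC(=O)Nc2cccc(Cl)c2)c2cc(Br)ccc2O1` gives 69000 nM
- compound 3 `COc1ccc(NC(=S)NC2CC(C)(C)Oc3ccc(Br)cc32)cc1` gives 40000 nM

Compound 3 at 40000 nM lies within the usual scatter of compound 1 at 27000 nM and also within the scatter of compound 2 at 69000 nM. Neither comparison separates compound 3 from its neighbour.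

The next compound is compound 4 `CC1(C)CC(NC(=S)Nc2cccc(C#N)c2)c2cc(Br)ccc2O1`, not yet measured. It has 3-cyanophenyl in place of 4-methoxyphenyl on an amide-type nitrogen, and the rest of compound 3 is kept: 3-cyanophenyl in place of 4-methoxyphenyl on an amide-type nitrogen.

Within the data shown here, no pair of measured compounds differs in one place only, so the data hold no direct measure of this exchange or of any other single change. A step no larger than the scatter is expected in this assay, with no firm direction. This expectation rests on compound 3 at 40000 nM, which stays within the scatter of both other compounds although each differs from it in more than one place. The estimated step of a 1.1-fold lower number from compound 3 to compound 4 (0.06 log units; within the scatter) is expected to stay within the scatter. For compound 4 the estimated value is 35000 nM, with an expected range of 14000 nM to 90000 nM and the measurement still to come.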

Compound 4, half-maximal inhibitory concentration: 6000 nM
Beside the measured number, compound 4's estimate is 5.8-fold (0.77 log units) above it, and the stated range ends above it.
By their numbers in this assay, from the lowest: compound 4; then compounds 1, 3 and 2 (each within the scatter of the next, the first and the last beyond it).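

In this assay, 3-cyanophenyl in place of 4-methoxyphenyl on an amide-type nitrogen, whose other neighbour is the thiocarbonyl carbon, gives a 6.7-fold lower number from compound 3 to compound 4 (0.82 log units; beyond the scatter). Among these compounds, this is the first change that can be read in one place, and it shows that the aryl group on this nitrogen matters to the read-out, which the earlier compounds, each differing in more than one place, could not show. The two groups have the same heavy-atom, donor and acceptor counts, so those counts do not separate them, and no measurement at hand bears on what lies behind the step.

One exchange cannot show whether the step belongs to the nitrile, to the loss of the methoxy group, or to the place each occupies on the phenyl ring. Also open, from the compounds shown here alone, is how this nitrogen responds to other groups on the phenyl ring, such as a carboxylic acid or an amine in place of the nitrile, and whether the same exchange carries over to a urea with the carbonyl in place of the thiocarbonyl.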